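The compounds below may be only part of what the source reports. "The series", "measured", "known", "first", "only" and "open" are said of these compounds alone.

Compound 1 `O=C(NCCC1CC1)c1ccc(N2CCC(Oc3ccccc3C(F)(F)F)CC2)nn1` is the starting point. Going by the values given here, in an assay on microsomes from liver for inhibition of acyl-CoA desaturase 1 (Rattus norvegicus) (on this read-out higher numbers stand for weaker inhibition and lower numbers for stronger inhibition), compound 1 gives 14 nM, and this is the lowest of the two numbers measured so far. The other measured compound, compound 2 `CC(=O)c1ccccc1OC1CCN(c2ccc(-n3ccnc3)nn2)CC1`, gives 34 nM in this assay; its number is higher than that of compound 1 by a margin beyond the usual scatter, so on these two values compound 1 is the stronger inhibitor.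

Compound 3 `Oc1nnc(-c2ccc(N3CCC(Oc4ccccc4C(F)(F)F)CC3)nn2)s1` has not yet been measured. It differs from compound 1 in one place: 5-hydroxy-1,3,4-thiadiazol-2-yl in place of (2-cyclopropylethyl)carbamoyl on an aromatic carbon. The whole of the shared core, including the trifluoromethyl-bearing ring and the piperidine linker, is kept; only the group on the six-membered ring with two nitrogens is exchanged.

Among the compounds with values here, no pair of measured compounds shows what such an exchange does in this assay, so the size of the step can only be guessed. The expectation is that compound 3 keeps inhibition of a similar order to compound 1, with a step from compound 1 to compound 3 of a 2.1-fold higher number from compound 1 to compound 3 (0.33 log units; beyond the scatter) toward a somewhat higher number, close to the edge of the scatter. Compound 3 is therefore estimated at 30 nM, within a range from 8 nM to 120 nM.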

Compound 3, half-maximal inhibitory concentration: 6.1 nM
Beside the measured number, compound 3's estimate is 4.9-fold (0.69 log units) above it; measured number below the stated range.
By their numbers in this assay, from the lowest: compound 3; then compound 1; then compound 2.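

In this assay, replacing the (2-cyclopropylethyl)carbamoyl chain with the 5-hydroxy-1,3,4-thiadiazol-2-yl ring gives a 2.3-fold lower number from compound 1 to compound 3 (0.36 log units; beyond the scatter) and thus a real, if small, gain in inhibition. This place, on an aromatic carbon of the six-membered aromatic ring with 2 nitrogen, therefore does not depend on the carbamoyl group or the three-membered carbon ring: a five-membered aromatic ring with 3 hetero atoms and fewer heavy atoms serves at least as well. No measurement shown here explains the gain.

The exchange changes the whole group at once, so the compounds shown do not separate the part played by the hydroxy from that of the ring carrying it, and a 1,3,4-thiadiazole without the hydroxy, or a carboxylic acid in the same place, would help to tell these apart. Compound 2 differs from compound 1 and compound 3 in more than one place, so it cannot show how other groups at this position compare.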